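This account rests on a few compounds, and the source may have more. Where it says the series, first, only, none or still open, it means among the compounds named here.

Compound 1 `Nc1ncnc2c1ncn2[C@@H]1O[C@H](COC(=O)OCc2ccccc2)[C@@H](O)[C@H]1O`: > 100000 nM in an assay on COS-7 cells for inhibition of sodium/nucleoside cotransporter 2 (Homo sapiens), read by scintillation counting, in the presence of a further agent that is not named here (on this read-out lower numbers stand for stronger inhibition and higher numbers for weaker inhibition), a limit only.
Compound 2 `CC(=O)OC[C@H]1O[C@@H](n2cnc3c(N)ncnc32)[C@H](O)[C@@H]1O`: > 100000 nM, a limit only.
Compound 3 `Nc1ncnc2c1nc(NCc1cccc(-c3ccccc3)c1)n2[C@@H]1O[C@H](CO)[C@@H](O)[C@H]1O`: 21000 nM.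

Compound 2 stands at the limit of > 100000 nM in this assay, at which 2 of the 3 values shown sit, so for it only a limit and no number is known. Compound 3 is the only one of the three with a measured number in this assay. Among the compounds with values here, the single one-place step, a step that the two limits leave unreadable from compound 1 to compound 2, is unreadable since both ends are limits. Compound 4 `Nc1ncnc2c1ncn2[C@@H]1O[C@H](COC(=O)NCc2ccccc2)[C@@H](O)[C@H]1O` differs from compound 2 by benzylamino in place of methyl on a carbonyl carbon. Within the data shown here, no measured step bears on this change. Compound 1, carrying benzyloxy on that carbonyl carbon, gives > 100000 nM, a limit. The step that the limit leaves unreadable from compound 2 to compound 4 is therefore expected to stay within the scatter. Compound 4 is expected to remain at the limit, with an estimate of 150000 nM in the range 30000 nM to 1000000 nM.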

Compound 4, half-maximal inhibitory concentration: > 100000 nM
Compound 4 gave a limit, no number; the forecaster's own chance of this, stated with the estimate: 75%; the middle value is on the limit's open side.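

Compound 4 gives only a limit, > 100000 nM, so no new step can be read among compound 1, compound 2 and compound 4. The compounds shown leave open whether benzylamino, benzyloxy and methyl on the carbonyl carbon differ at all in this assay.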